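Methoxy for methyl on an aminothiadiazole series

The source may report more compounds than this note shows. Statements on the series, on what has been measured and on what is new or still open speak of the compounds shown alone.

Compound 2 `Cc1ccc(Nc2nnc(-c3cc(-c4ccc(F)cc4F)ccc3O)s2)cc1` gives 43.5% in a functional assay on the whole organism (strain BALB/c) for inhibition, with Mus musculus as the target, read by paw edema, with a stated time of 4 h, at a dose of 50 mg/kg by the oral route (on this read-out lower numbers stand for less inhibition and higher numbers for more inhibition at the one dose given (going by the name of the read-out)), and compound 1 `Oc1ccc(-c2ccc(F)cc2F)cc1-c1nnc(NC2CCCCC2)s1` gives 41.4%; the two lie within the scatter of each other, as the step of a number 2.1 percentage points higher from compound 1 to compound 2 (within the scatter) shows. Compound 3 `COc1ccc(Nc2nnc(-c3cc(-c4ccc(F)cc4F)ccc3O)s2)cc1` differs from compound 2 by methoxy in place of methyl on an aromatic carbon. For the measured compounds named here, no measured step alters a group on that ring, and the only step recorded, from cyclohexyl to 4-methylphenyl, was within the scatter, so no change beyond the scatter is expected. Compound 3 is therefore expected to give 43%, between 30% and 56%, a step of a number 0.5 percentage points lower from compound 2 to compound 3 (within the scatter).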

Compound 3, a percentage reported as inhibition, in the whole organism at one dose (the size of the read-out at that dose, not a potency): 55.3%
Beside the measured number, compound 3's estimate is 12.3 percentage points below it; measured number inside the range.
By their numbers in this assay, from the lowest: compounds 1 and 2 (each within the scatter of the next); then compound 3.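

In this assay, for the compounds shown here, the group para to a large group on the aromatic ring proves able to move the read-out: methoxy in place of methyl gives a number 11.8 percentage points higher from compound 2 to compound 3 (beyond the scatter), whereas the only earlier step, from cyclohexyl to 4-methylphenyl, stayed within the scatter. Putting 4-methoxyphenyl in place of cyclohexyl gives a number 13.9 percentage points higher from compound 1 to compound 3 (beyond the scatter), so this aromatic ring clears the scatter only when it carries methoxy. No evidence at hand bears on what lies behind this result. The compounds shown leave open whether ethoxy or a dimethylamino group at this place would match compound 3.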